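A few compounds are considered here, and "the series" means these few. Any claim that something is new, unique, unknown or untested is made for them only; others in the source may bear on it.

Within the data shown here, compound 1 `CCOC(=O)N1CCC(NS(=O)(=O)c2ccc(NC(=O)c3ccccc3)c3ccccc23)CC1` gives 0.17 nM in an assay on L1.2 cells for binding affinity to C-C chemokine receptor type 8 (Homo sapiens) (a higher number here means a weaker inhibitor, a lower number a stronger inhibitor), compound 2 `CCOC(=O)N1CCC(NS(=O)(=O)c2ccc(OC(=O)c3ccccc3)c3ccccc23)CC1` gives 16.4 nM, and the step of a 96-fold higher number from compound 1 to compound 2 (1.98 log units; beyond the scatter) is the only one-place change measured here. Compound 3 `Cc1ccccc1C(=O)Nc1ccc(S(=O)(=O)NC2CCN(C(=O)C3CCCC3)CC2)c2ccccc12` gives 9.1 nM, the second highest of the three numbers; it lies within the scatter of compound 2 and well beyond the scatter of compound 1. Compound 4 `Cc1ccccc1C(=O)Nc1ccc(S(=O)(=O)NC2CCN(C(=O)NC(C)C)CC2)c2ccccc12` differs from compound 3 by isopropylamino in place of cyclopentyl on a carbonyl carbon. Among the measured compounds shown here, no measured step touches this carbonyl carbon, so nothing here indicates the direction of the change. Compound 4 is therefore expected to stay close to compound 3, with a 1.0-fold lower number from compound 3 to compound 4 (0.00 log units; within the scatter) judged to fall within the scatter, and its estimate is 9 nM, in a range from 2.5 nM to 30 nM.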

Compound 4, inhibition constant: 77.7 nM
Compound 4: the middle estimate sits 8.6-fold (0.94 log units) below what was measured; measured number above the stated range.
By their numbers in this assay, from the lowest: compound 1; then compounds 3 and 2 (each within the scatter of the next); then compound 4.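

At this carbonyl carbon, in this assay, isopropylamino in place of cyclopentyl gives an 8.5-fold higher number from compound 3 to compound 4 (0.93 log units; beyond the scatter) and so yields a weaker inhibitor. The position is therefore sensitive to what it carries, at least for this pair. The change removes the ring and adds a hydrogen-bond donor, and nothing available shows which of these differences matters.

As far as these compounds go, whether cyclopentylamino, which keeps the ring and the amide hydrogen, or dimethylamino, which has no amide hydrogen, would stay nearer compound 3 or compound 4 remains open.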